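The source may hold more compounds than are shown below. What is called first, only, known or untested is meant among the compounds shown, and "the series" means these compounds.

Three compounds share one core and differ in the chain and in the phenol ring at its end. In an assay on HEK293 cells for displacement of a labelled ligand from D(3) dopamine receptor (Rattus norvegicus), with a stated time of 1 h (a lower number here means a stronger inhibitor, a higher number a weaker inhibitor), compound 1, with structure `CCCN(CCC/C=C/c1ccc(O)c(OC)c1)[C@H]1CCc2nc(N)sc2C1`, gives 22.3 nM, the highest of the three numbers. Compound 2, `CCCN(CCCc1ccc(O)c(O)c1)C1CCc2nc(N)sc2C1`, gives 11.9 nM, which sits within the usual scatter of compound 1. Compound 3, `CCCN(CCCCCc1cc(O)ccc1O)[C@H]1CCc2nc(N)sc2C1`, gives 0.78 nM, a number beyond the scatter below compound 1. Compound 4, `CCCN(CCC/C=C/c1ccc(O)c(OC)c1)C1CCc2nc(N)sc2C1`, has not yet been measured. Its difference from compound 1 is the two compounds have the same atoms and bonds; at least one stereo element is drawn with a configuration in one of them and without one in the other: 1 of 2 stereo elements differ; a stereocentre at a saturated ring carbon is drawn S in compound 1 and without a configuration in compound 4: the two compounds have the same atoms and bonds, and the stereocentre at a saturated ring carbon that is drawn S in compound 1 is drawn without a configuration in compound 4. Within the data shown here, no measured pair shows what this change does. The step expected here, a 1.4-fold higher number from compound 1 to compound 4 (0.16 log units; within the scatter), is small, toward a weaker inhibitor if anything, and may lie within the scatter. Compound 4 is estimated at 32 nM, within 10 nM to 100 nM.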

Compound 4, inhibition constant: 4.24 nM
Compound 4: the middle estimate sits 7.5-fold (0.88 log units) above what was measured; the whole stated range lies above it.
By their numbers in this assay, from the lowest: compound 3; then compound 4; then compounds 2 and 1 (each within the scatter of the next).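

Among these compounds, changing only how one saturated ring carbon is drawn gives a 5.3-fold lower number from compound 1 to compound 4 (0.72 log units; beyond the scatter) in this assay, so this stereocentre matters for this receptor, which the earlier compounds could not show. The S form is therefore not the better one here, and the only structural difference that can account for the step is this: the fact that one of compounds 1 and 4 is drawn with a defined configuration and the other without, at the place where they differ

Going by these compounds, whether compound 4 is a mixture stays open, as does how a form drawn R with the same chain would compare. The effect of a fluorine on the phenol ring is also unknown.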